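A few compounds are considered here, and "the series" means these few. Any claim that something is new, unique, unknown or untested is made for them only; others in the source may bear on it.

In a functional assay on QGY-7703 cells (Homo sapiens) for cytotoxicity, read by MTT assay, with a stated time of 24 h (on this read-out higher numbers stand for weaker inhibition and lower numbers for stronger inhibition), compound 1 `COc1cc(/C=C2\CN(S(=O)(=O)c3ccc(F)cc3)C/C(=C\c3cc(OC)c(OC)c(OC)c3)C2=O)cc(OC)c1OC` gives 2220 nM, within the scatter of compound 3 `COc1cc(/C=C2\CN(S(=O)(=O)c3ccc(NC(C)=O)cc3)C/C(=C\c3cc(OC)c(OC)c(OC)c3)C2=O)cc(OC)c1OC` at 1900 nM, while compound 2 `CC(=O)Nc1ccc(S(=O)(=O)N2C/C(=C\c3cccc([N+](=O)[O-])c3)C(=O)/C(=C/c3cccc([N+](=O)[O-])c3)C2)cc1` reads higher at 6760 nM. Compound 4 `COc1cc(/C=C2\CN(S(=O)(=O)c3ccc(F)cc3)C/C(=C\c3ccccc3F)C2=O)cc(OC)c1OC` differs from compound 1 by 2-fluorophenyl in place of 3,4,5-trimethoxyphenyl on a double-bonded chain carbon bound to a double-bonded ring carbon. Among the measured compounds shown here, the only measured step, a 1.2-fold lower number from compound 1 to compound 3 (0.07 log units; within the scatter), lies at another place and gives no guide here. Compound 2, with no 3,4,5-trimethoxyphenyl group, shows 6760 nM, which weakly suggests a higher number, though it differs in other groups too. The expected change is modest, a 1.4-fold higher number from compound 1 to compound 4 (0.16 log units; within the scatter), and may not clear the scatter. For compound 4 the estimated value in this assay is 3200 nM, with an expected range of 1100 nM to 9000 nM.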

Compound 4, half-maximal inhibitory concentration: 13300 nM
Estimate against measurement, compound 4: 4.2-fold (0.62 log units) below; the whole stated range lies below it.
By their numbers in this assay, from the lowest: compounds 3 and 1 (each within the scatter of the next); then compounds 2 and 4 (each within the scatter of the next).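

In this assay, the aryl group on a double-bonded chain carbon bound to a double-bonded ring carbon matters: the change to 2-fluorophenyl from 3,4,5-trimethoxyphenyl gives a 6.0-fold higher number from compound 1 to compound 4 (0.78 log units; beyond the scatter), even though compound 4 keeps the other 3,4,5-trimethoxyphenyl group. Among the compounds shown here, the one earlier step with matched structures, at another place, stayed within the scatter. No available evidence bears on the cause of this step.

As far as these compounds go, it remains open whether the step follows the loss of the methoxy groups or the entry of fluorine. An unsubstituted phenyl group at this place would separate the two.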